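A few compounds are considered here, and "the series" means these few. Any claim that something is new, unique, unknown or untested is made for them only; others in the source may bear on it.

Compound 1 `CCOC(=O)CCCCCOc1cccc(CN(C(=O)c2ccc(-c3cccc4ccccc34)cc2)C(C)C)c1`: in an ADME assay on HEK293 cells (Homo sapiens) for cytotoxicity, read by CellTiter-Glo and resazurin assay, with a stated time of 72 h (on this read-out lower numbers stand for an effect already at smaller amounts and higher numbers for an effect only at larger amounts of compound), compound 1 reaches only the limit of > 26000 nM.
Compound 2 `CCOC(=O)CCCCCOc1cccc(CN(C(=O)c2ccc(-c3ccco3)cc2)C(C)C)c1`: in this assay compound 2 likewise stops at the limit of > 26000 nM.
Compound 3 `CCOC(=O)CCCCCOc1cccc(CN(C(=O)c2ccc(-c3cccc(OC(F)(F)F)c3)cc2)C(C)C)c1`: in this assay compound 3 also gives only the limit of > 26000 nM.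

Compound 3 thus stands at the limit shared by every compound measured here, the point described by the limit of > 26000 nM in this assay, at which 3 of the 3 values shown sit. The next compound, compound 4 `CCOC(=O)CCCCCOc1cccc(CN(C(=O)c2ccc(-c3cc(OC)ccc3F)cc2)C(C)C)c1`, differs from compound 3 in one place: 2-fluoro-5-methoxyphenyl in place of 3-(trifluoromethoxy)phenyl on an aromatic carbon. The measured steps nearest to it are a step that the two limits leave unreadable from compound 1 to compound 3, a step that the two limits leave unreadable from compound 2 to compound 3 and a step that the two limits leave unreadable from compound 1 to compound 2; none of them can be read in size, since both ends sit at the limit. All three aryl changes so far left this assay without an effect inside the tested range, so no step beyond the scatter is expected here either, with a number no higher from compound 3 to compound 4 (the limit leaves the size open). Compound 4 is therefore expected to remain at the limit, estimated at 26000 nM with a range from 15000 nM to 40000 nM.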

Compound 4, half-maximal effective concentration: > 26000 nM
Compound 4: a limit, no number (the forecaster's own chance of this, stated with the estimate: 85%); the middle value lies on the limit itself.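

Compound 4, like compound 1, compound 2 and compound 3, gives only a limit, so none of the steps to compound 4 can be read. The compounds shown leave open what actual number any of them would reach in this assay.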